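The source may hold more compounds than are shown below. What is called first, only, known or untested is meant among the compounds shown, and "the series" means these compounds.

Compound 1, `COc1ccc(-c2cc3ccccc3nc2/C=C/C(=O)c2ccc(F)cc2)cc1`, gives 810 nM in a functional assay on SK-BR-3 cells (Homo sapiens) for antiproliferative activity, read by XTT assay, with a stated time of 72 h; on this read-out higher numbers stand for weaker inhibition and lower numbers for stronger inhibition.
Compound 2, `COc1ccc(-c2cc3ccccc3nc2/C=C/C(=O)c2ccc(OC)cc2OC)cc1`, gives 2260 nM in this assay.
Compound 3, `COc1ccc(-c2cc3ccccc3nc2/C=C/C(=O)c2ccc([N+](=O)[O-])cc2)cc1`, gives 590 nM in this assay.

Among these three, compound 3 stands at the lowest number in this assay. Its gap to compound 1 is within the scatter, so those two cannot be ordered; the only gap that is beyond the scatter is this one: a 3.8-fold lower number from compound 2 to compound 3 (0.58 log units; beyond the scatter).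

Compound 4, `COc1ccc(-c2cc3ccccc3nc2/C=C/C(=O)c2ccsc2)cc1`, differs from compound 3 in one place: thiophen-3-yl in place of 4-nitrophenyl on a carbonyl carbon. All three measured steps concern the same position, the aryl group on the carbonyl carbon, and all were modest at most: a 2.8-fold higher number from compound 1 to compound 2 (0.45 log units; beyond the scatter), a 1.4-fold lower number from compound 1 to compound 3 (0.14 log units; within the scatter), a 3.8-fold lower number from compound 2 to compound 3 (0.58 log units; beyond the scatter). Among the compounds with values here, none of them involves a five-membered aromatic ring with one hetero atom, so there is no direct precedent for the thiophen-3-yl group. Because compound 3 holds the lowest number with 590 nM and the exchange removes the group carrying it, compound 4 is expected to give a somewhat higher number, with an expected step of a 1.7-fold higher number from compound 3 to compound 4 (0.23 log units; within the scatter). Compound 4 is therefore estimated at 1000 nM, expected to fall between 400 nM and 2500 nM.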

Compound 4, half-maximal inhibitory concentration: 660 nM
The estimate for compound 4 lay 1.5-fold (0.18 log units) above the measured number; the range from low to high includes it.
By their numbers in this assay, from the lowest: compounds 3, 4 and 1 (each within the scatter of the next); then compound 2.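

In this assay, the position on the carbonyl carbon tolerates a five-membered aromatic ring with 1 hetero atom: replacing 4-nitrophenyl with the smaller thiophen-3-yl gives a 1.1-fold higher number from compound 3 to compound 4 (0.05 log units; within the scatter), and replacing 4-fluorophenyl with it gives a 1.2-fold lower number from compound 1 to compound 4 (0.09 log units; within the scatter). A nitro group or a fluoro group on a six-membered aromatic ring is therefore not needed to reach this level, and among the four compounds only the 2,4-dimethoxyphenyl group stands apart, with a 3.4-fold lower number from compound 2 to compound 4 (0.53 log units; beyond the scatter). No measurement shown here accounts for this grouping.

Going by these compounds, it remains open whether a pyridine ring, an amine or a carboxylic acid on this carbonyl carbon would stay at the same level. On these data alone, all four compounds share the rest of the structure, so how the numbers respond to changes elsewhere also remains unknown.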